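The compounds below may be only part of what the source reports. "The series", "measured", "known", "first", "only" and "open" are said of these compounds alone.

Measured so far in a functional assay on cells (Rhabdomyosarcoma cell, Homo sapiens) for cytotoxicity; on this read-out lower numbers stand for stronger inhibition and higher numbers for weaker inhibition:
Compound 1 `Cc1ccsc1C(c1c(C)noc1C)N1CCN(c2ncnc3c2cnn3-c2ccccc2)CC1` gives > 25000 nM, which is a limit of this assay and not a number.
Compound 2 `c1ccc(C(c2ccco2)N2CCN(c3ncnc4c3cnn4-c3ccccc3)CC2)cc1` gives > 25000 nM, again only a limit.
Compound 3 `Cc1ccsc1C(c1ccccc1Br)N1CCN(c2ncnc3c2cnn3-c2ccccc2)CC1` gives > 25000 nM, also only a limit.

Compound 2 therefore stands at the limit of > 25000 nM in this assay, at which 3 of the 3 values shown sit, and no number for its potency in this assay is known. Compound 4 `c1ccc(C(c2ccncc2)N2CCN(c3ncnc4c3cnn4-c3ccccc3)CC2)cc1` differs from compound 2 in one place: pyridin-4-yl in place of furan-2-yl on a saturated chain carbon bound to an amine nitrogen in a ring and an aromatic carbon. Within the data shown here, the only measured step that swaps the group on this same saturated chain carbon is a step that the two limits leave unreadable from compound 1 to compound 3; both of its ends are limits, so its size is not readable. Nothing measured therefore tells how large the step to compound 4 should be, or in which direction. With all three measured values sitting at the limit of > 25000 nM in this assay, at which 3 of the 3 values shown sit, the plainest expectation is that compound 4 also returns only a limit in this assay, the expected step being a step that the limit leaves unreadable from compound 2 to compound 4. Compound 4 is estimated at 50000 nM, between 20000 nM and 200000 nM.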

Compound 4, half-maximal inhibitory concentration: > 25000 nM
Compound 4 gave a limit, no number (the forecaster's own chance of this, stated with the estimate: 85%); the middle value is on the limit's open side.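

Compound 2 and compound 4 both give only a limit in this assay, not a number, so no step between them can be read: the limit of > 25000 nM in this assay, at which 4 of the 4 values shown sit.

The compounds shown leave open how potent any of them really is, and whether changing the group on this saturated chain carbon alters potency at all.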